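One Fluorine Fewer: Expected Cytotoxicity of Compound 4

The compounds below may be only part of what the source reports. "The series", "measured", "known", "first", "only" and "open" are said of these compounds alone.

Of the compounds shown here, three built on one shared core have been tested in a toxicity assay on HepG2 2.2.15 cells (Homo sapiens) for cytotoxicity, read by CCK-8 assay, with a stated time of 8 days; on this read-out lower numbers stand for higher toxicity in this test and higher numbers for lower toxicity in this test. Compound 1 `CC(C)Cc1nn(-c2cccc(F)c2)cc1C(=O)NCC1CCN(C(=O)OC(C)(C)C)CC1` reaches only the limit of the assay, reported as > 100000 nM. That boundary, (the limit of > 100000 nM in this assay, at which 1 of the 3 values shown sits), is a limit rather than a measured number. Compound 2 `CC(C)Cc1nn(-c2cccc(F)c2)cc1C(=O)NCc1ccccc1` gives 85900 nM in this assay, and compound 3 `CC(C)Cc1nn(-c2nccs2)cc1C(=O)NCc1ccc(F)cc1F` gives 83600 nM; these two numbers sit within the usual scatter of each other, so neither compound can be called more or less toxic than the other. Among the compounds with values here, no two of the measured compounds differ in a single place, so no measured step exists to lean on.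

Compound 4 `CC(C)Cc1nn(-c2nccs2)cc1C(=O)NCc1ccc(F)cc1` differs from compound 3 by hydrogen in place of fluoro on an aromatic carbon. A change this small, without measured precedent here, is expected to shift the read-out by no more than the scatter in either direction. The step is estimated as a 1.0-fold higher number from compound 3 to compound 4 (0.01 log units; within the scatter). Compound 4 is expected to give about 85000 nM, within a range from 45000 nM to 150000 nM, with a fair chance that only a limit is reported.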

Compound 4, half-maximal cytotoxic concentration: > 100000 nM
Compound 4 ended at the assay's limit; the forecaster's own chance of this, stated with the estimate: 35%; middle value at least 1.1-fold (0.07 log units) from the limit.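

Within the data shown here, removing the fluoro group that sits ortho to a large group, which turns the 2,4-difluorophenyl into 4-fluorophenyl, gives the first measured single-place step: in this assay the read-out shows an at least 1.1-fold higher number from compound 3 to compound 4 (0.07 log units; that floor lies within the scatter). Compound 4 gives > 100000 nM, which is a limit and not a measured number. This fluoro group is therefore not needed for the read-out to stay at the low-toxicity end of this test, but the true size of the step cannot be read, and the ceiling of the test now limits what the series can show: the limit of > 100000 nM in this assay, at which 2 of the 4 values shown sit.

The compounds shown leave open how a chlorine, a methoxy group or an amine would read on this same aromatic carbon. They also leave open whether the same swap of fluoro for hydrogen would read alike on compounds that differ elsewhere on the shared core.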